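The source may hold more compounds than are shown below. What is called first, only, known or untested is meant among the compounds shown, and "the series" means these compounds.

Of the compounds shown here, two have been measured in a functional assay for inhibition, with stated times of 20 min and 60 min, tested at 100 uM; on this read-out higher numbers stand for a stronger effect at the one concentration tested and lower numbers for a weaker effect. Compound 1 `COc1ccc(CCOC(=O)CCc2ccccc2)cc1OC` returns only a limit of the assay there, < 10%. On the numbers shown compound 1 sits at the limit of < 10% in this assay, at which 1 of the 2 values shown sits. Among the measured compounds shown here, compound 2 `CCCCCCC(=O)/C=C/c1ccc(O)c(O)c1` gives 48% in this assay, the only number among the values shown. Compound 3 `CCCCCNC(=O)/C=C/c1ccc(O)c(O)c1` differs from compound 2 by pentylamino in place of hexyl on a carbonyl carbon. For the measured compounds named here, no step between measured compounds is available, so the expectation rests on compound 2 alone; the step is estimated as a modest fall of a number 13 percentage points lower from compound 2 to compound 3 (beyond the scatter), at the edge of the scatter. Compound 3 is thus expected to give 35%, in the range 10% to 60%.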

Compound 3, a percentage reported as inhibition, at one concentration (the size of the read-out at that concentration, not a potency): 40%
Estimate against measurement, compound 3: 5 percentage points below; low and high end bracket the measured number.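

Among the compounds shown here, on a carbonyl carbon, pentylamino in place of hexyl is the first one-place change, and in this assay it gives a number 8 percentage points lower from compound 2 to compound 3 (within the scatter). This position therefore accepts a nitrogen in place of a chain carbon with no step beyond the scatter. Compound 2 and compound 3 both stand clear of the limit of the read-out: the limit of < 10% in this assay, at which 1 of the 3 values shown sits.

As far as these compounds go, whether a carboxylic acid, an ester or a longer chain on the same carbonyl carbon would hold this effect stays open. From the compounds shown here alone, with one concentration only, how the effects of compound 2 and compound 3 would compare at other concentrations also stays open.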